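A few compounds are considered here, and "the series" means these few. Any claim that something is new, unique, unknown or untested is made for them only; others in the source may bear on it.

Measured so far:
Compound 1 `COc1ccc(NC(=O)Nc2nc(Sc3c[nH]c4ccccc34)cc(N3CCN(c4ccccn4)CC3)n2)cc1`: in a functional assay on A549 cells (Homo sapiens) for inhibition, with a stated time of 72 h (on this read-out lower numbers stand for stronger inhibition and higher numbers for weaker inhibition), compound 1 gives > 50000 nM, which is a limit of the assay.
Compound 2 `COc1ccc(NC(=O)Nc2nc(Sc3c[nH]c4ccccc34)cc(N3CCCC3)n2)cc1`: in this assay compound 2 gives 11800 nM.

Compound 1 therefore stands only at the limit of > 50000 nM in this assay, at which 1 of the 2 values shown sits. Compound 3 `COc1ccc(NC(=O)Nc2nc(Sc3c[nH]c4ccccc34)cc(N3CCN(Cc4ccccc4)CC3)n2)cc1` differs from compound 1 by benzyl in place of pyridin-2-yl on an amine nitrogen in a ring. For the measured compounds named here, no measured step changes this group alone; the one measured step, an at least 4.2-fold lower number from compound 1 to compound 2 (0.62 log units; beyond the scatter), removes the whole ring that bears it. Since compound 3 keeps that ring and the step of an at least 4.2-fold lower number from compound 1 to compound 2 (0.62 log units; beyond the scatter) does not touch its substituent, compound 3 is expected to move little, giving the expected step of an at least 1.4-fold lower number from compound 1 to compound 3 (0.15 log units; that floor lies within the scatter). For compound 3 the estimate in this assay is 35000 nM, within 12000 nM to 100000 nM.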

Compound 3, half-maximal inhibitory concentration: 42300 nM
The estimate for compound 3 lay 1.2-fold (0.08 log units) below the measured number, within the range that was stated.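

Exchanging pyridin-2-yl for benzyl gives an at least 1.1-fold lower number from compound 1 to compound 3 (0.07 log units; that floor lies within the scatter). This swap between two groups that each carry a six-membered aromatic ring therefore shows no change beyond the scatter, and compound 3 gives a number that can be read. Compound 1 has only a limit, so the true size of this step stays unknown: the limit of > 50000 nM in this assay, at which 1 of the 3 values shown sits.

The compounds shown leave open how a methyl or an acetyl group on that same nitrogen would fare. They also leave open whether an amine or a carboxylic acid on the benzyl ring would move the number.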